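Aryl swap on the sulfonyl sulfur: compound 2 to compound 3

A few compounds are considered here, and "the series" means these few. Any claim that something is new, unique, unknown or untested is made for them only; others in the source may bear on it.

Measured in a functional assay on A549 cells (Homo sapiens) for antiproliferative activity, read by MTT assay, with a stated time of 48 h; on this read-out lower numbers stand for stronger inhibition and higher numbers for weaker inhibition:
- compound 1 `Cn1cc(-c2cnc3ccc(NC(=O)C4CC4)nc3c2)cn1`: > 50000 nM
- compound 2 `Cc1ccc(S(=O)(=O)Nc2ccc3ncc(-c4cnn(C)c4)cc3n2)cc1`: 45500 nM

The entry for compound 1 is a limit of the assay and not a number. Among the compounds with values here, compound 2 therefore holds the only actual number, 45500 nM.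

Compound 3 `Cn1cc(-c2cnc3ccc(NS(=O)(=O)c4ccc(Cl)cc4Cl)nc3c2)cn1` carries 2,4-dichlorophenyl in place of 4-methylphenyl on a sulfonyl sulfur. Within the data shown here, no measured pair isolates a change of this kind, so any expectation for its size is loose. A modest move toward stronger inhibition is expected, because compound 2 at 45500 nM leaves little room on the weaker side. The expected change is a 2.3-fold lower number from compound 2 to compound 3 (0.36 log units; beyond the scatter). In this assay the estimated value for compound 3 is 20000 nM, with an expected range from 5000 nM to 50000 nM.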

Compound 3, half-maximal inhibitory concentration: > 50000 nM
Compound 3: a limit, no number; the forecaster's own chance of this, stated with the estimate: 25%; middle value at least 2.5-fold (0.39 log units) from the limit.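

In this assay compound 3 gives > 50000 nM, a limit of the assay and not a number. Within the data shown here, with 2,4-dichlorophenyl in place of 4-methylphenyl on a sulfonyl sulfur, the step reads an at least 1.0-fold higher number from compound 2 to compound 3 (0.04 log units; that floor lies within the scatter), so this change brings no move toward stronger inhibition and 4-methylphenyl remains the only aryl group on this sulfur with an actual number. The true size of the step cannot be read because of the assay limit: the limit of > 50000 nM in this assay, at which 2 of the 3 values shown sit.

As far as these compounds go, whether any group on this sulfur can bring the number clearly down remains open, for instance 4-aminophenyl, a 4-carboxyphenyl or a plain methyl. Also open is how 2,4-dichlorophenyl would compare with a single chlorine on the phenyl ring, since the compounds shown do not separate the two chlorines.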